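Phenyl for 3,5-difluorophenyl on the sulfonyl sulfur

The source may hold more compounds than are shown below. What is called first, only, known or untested is meant among the compounds shown, and "the series" means these compounds.

- compound 1 `O=C(NCc1ccc(S(=O)(=O)c2ccccc2)cc1)c1cc2ncccc2s1` gives 1.6%
- compound 2 `O=C(NCc1ccc(S(=O)(=O)c2ccccc2)cc1)c1ccc2nccn2c1` gives 18%
- compound 3 `O=C(NCc1ccc(S(=O)(=O)c2cc(F)cc(F)c2)cc1)c1cnc2nccn2c1` gives 71%

In an ADME assay on microsomes from liver (Mus musculus) for metabolic stability, read by LC-MS, with a stated time of 30 min, tested at 1 uM (on this read-out lower numbers stand for a less stable compound and higher numbers for a more stable compound), compound 3 ranks highest (71%) of the three, beyond the scatter from both others. Compound 4 `O=C(NCc1ccc(S(=O)(=O)c2ccccc2)cc1)c1cnc2nccn2c1` has phenyl in place of 3,5-difluorophenyl on a sulfonyl sulfur. Among the measured compounds shown here, the only measured step (a number 16.4 percentage points higher from compound 1 to compound 2 (beyond the scatter)) was modest and sits elsewhere, on a carbonyl carbon, so it does not size this change. For the measured compounds named here, compound 2 also carries phenyl, with a low value (18%), but its core differs from that of compound 3, so no measured pair isolates the fluorines. In this assay a sizeable downward step is therefore expected (a number 26 percentage points lower from compound 3 to compound 4 (beyond the scatter)). The estimate for compound 4 is 45% with an expected range (22% to 68%).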

Compound 4, percent of the compound remaining: 30%
Beside the measured number, compound 4's estimate is 15 percentage points above it, within the range that was stated.
By their numbers in this assay, from the lowest: compound 1; then compound 2; then compound 4; then compound 3.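

In this assay, phenyl in place of 3,5-difluorophenyl on the sulfonyl sulfur gives a number 41 percentage points lower from compound 3 to compound 4 (beyond the scatter) on an unchanged core, the first read of this position alone. The steps on the carbonyl carbon are modest by comparison, with a number 12 percentage points higher from compound 2 to compound 4 (beyond the scatter) and a number 28.4 percentage points higher from compound 1 to compound 4 (beyond the scatter), so this large step is the biggest single-place change in the set. No measurement offered here accounts for the size of the step at the sulfonyl sulfur.

Going by these compounds, whether cyclohexyl or pyridyl on the sulfonyl sulfur would match 3,5-difluorophenyl remains open. So does whether 3,5-difluorophenyl gives a similar step on the core of compound 1 or compound 2.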